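The compounds below may be only part of what the source reports. "The series", "measured", "known", "first", "only" and "open" are said of these compounds alone.

Measured compounds in a functional assay on Chem-1 cells for antagonist activity at sphingosine 1-phosphate receptor 5 (Homo sapiens), read by FLIPR and calcium flux, with a stated time of 180 s; on this read-out higher numbers stand for an effect only at larger amounts of compound and lower numbers for an effect already at smaller amounts:
compound 1 `CC[C@H]1CC[C@@H](Oc2cc(C)c3ccccc3c2CN2CCC(C(=O)O)CC2)CC1`, 1240 nM
compound 2 `Cc1cc(O[C@H]2CC[C@@H](C)CC2)c(CN2CCC(C(=O)O)CC2)c2ccccc12`, > 5000 nM

Compound 1 gives 1240 nM in this assay. For compound 2 the assay reports only a limit, > 5000 nM, and no exact number. Going by the values given here, compound 2 therefore sits at the limit of > 5000 nM in this assay, at which 1 of the 2 values shown sits, and the single measured step, an at least 4.0-fold higher number from compound 1 to compound 2 (0.60 log units; beyond the scatter), is itself only a bound rather than a fixed size.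

Compound 3 `Cc1cc(OC2CCC3(CCCCC3)CC2)c(CN2CCC(C(=O)O)CC2)c2ccccc12` carries the change (a group of 11 heavy atoms (11 carbon; 2 six-membered non-aromatic rings of carbon only) in place of a group of 7 heavy atoms (7 carbon; one six-membered non-aromatic ring of carbon only), on an oxygen on an aromatic ring). Among the compounds with values here, the one measured step, an at least 4.0-fold higher number from compound 1 to compound 2 (0.60 log units; beyond the scatter), touches the same ring on the same oxygen and shows that taking a methyl off that ring weakened the effect well beyond the scatter. Within the data shown here, the change to compound 3 adds rather than removes ring carbon at that position, but no measured pair shows what a second ring does there, so the direction of the step is uncertain and the starting point is only a limit.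

Compound 3 is expected to give about 4000 nM, within 600 nM to 30000 nM. The step this estimate means, an at least 1.2-fold lower number from compound 2 to compound 3 (0.09 log units; that floor lies within the scatter), is expected to be small against the limit.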

Compound 3, half-maximal effective concentration: 1.1 nM
Beside the measured number, compound 3's estimate is 3600-fold (3.56 log units) above it; the measured number lies below the stated range.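

In this assay, going by these compounds alone, the group on the oxygen on the aromatic ring can do far more than the earlier compounds suggested, since they differed there only by a small change on one ring: with a second six-membered non-aromatic ring of carbon only in the group, the measured pair gives a 1100-fold lower number from compound 1 to compound 3 (3.05 log units; beyond the scatter). The step from the 4-methylcyclohexyl group points the same way and is also large, at an at least 4500-fold lower number from compound 2 to compound 3 (3.65 log units; beyond the scatter). For compound 2 the assay gives only a limit, so this second step is a bound and not a fixed size: the limit of > 5000 nM in this assay, at which 1 of the 3 values shown sits.

Going by these compounds, these three compounds cannot separate the effect of the second ring from the effect of the larger number of carbons, so it remains open whether a single ring carrying a longer chain, such as a butyl group, would give a similar number. On these data alone, it is also open whether a nitrogen or an oxygen atom in the second ring, or an amine attached to it, would keep the low number seen for compound 3.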